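Ring expansion at the ketone of compound 1

The source may report more compounds than this note shows. Statements on the series, on what has been measured and on what is new or still open speak of the compounds shown alone.

For the measured compounds named here, compound 1 `NS(=O)(=O)c1ccc(N2C(=O)CC(C3CCCCC3=O)C2=O)cc1` gives 21300 nM in an assay on Sf21 cells for inhibition of cytochrome c oxidase subunit 2 (Homo sapiens), read by spectrophotometry, with a stated time of 5 min (on this read-out higher numbers stand for weaker inhibition and lower numbers for stronger inhibition), the lower of the two numbers so far. Compound 2 `O=C1CCCCC1C1CC(=O)N(c2ccccc2)C1=O` gives 45100 nM in this assay, and the step of a 2.1-fold higher number from compound 1 to compound 2 (0.33 log units; beyond the scatter) is the only measured one; it concerns the aromatic substituent, not the saturated ring. Going by the values given here, compound 3 `NS(=O)(=O)c1ccc(N2C(=O)CC(C3CCCCCC3=O)C2=O)cc1` carries 2-oxocycloheptyl in place of 2-oxocyclohexyl on a saturated ring carbon, a change on which no measured step bears. Among the compounds with values here, without a comparable step, and with the one measured step only modest, no movement beyond the scatter is expected. Compound 3 is therefore expected at 22000 nM, between 8000 nM and 60000 nM, an expected step of a 1.0-fold higher number from compound 1 to compound 3 (0.01 log units; within the scatter).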

Compound 3, half-maximal inhibitory concentration: 20700 nM
Beside the measured number, compound 3's estimate is 1.1-fold (0.03 log units) above it; measured number inside the range.
By their numbers in this assay, from the lowest: compounds 3 and 1 (each within the scatter of the next); then compound 2.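

For the compounds shown here, putting 2-oxocycloheptyl in place of 2-oxocyclohexyl gives the first measured step at this saturated ring carbon in this assay, a 1.0-fold lower number from compound 1 to compound 3 (0.01 log units; within the scatter). The six-membered and seven-membered ketone rings therefore cannot be told apart on this read-out, and the sulfamoyl step remains the only one beyond the scatter. No available evidence bears on this result.

From the compounds shown here alone, whether 2-oxocyclopentyl, an open-chain ketone or a hydroxyl group in place of the ring carbonyl would read the same remains open. So does whether removing sulfamoyl has the same effect with the seven-membered ring present.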